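The source may report more compounds than this note shows. Statements on the series, on what has been measured and on what is new or still open speak of the compounds shown alone.

Compound 1 `CC/N=C(/N)Nc1nc(-c2ccc(OC)cc2)c(-c2ccc(OC)cc2)s1`: in a functional assay with Oryctolagus cuniculus as the target (a lower number here means a stronger inhibitor, a higher number a weaker inhibitor), compound 1 gives > 100 nM, which is a limit of the assay. Compound 2 `COc1ccc(-c2nc(/N=C(\N)NC(C)C)sc2-c2ccc(OC)cc2)cc1`: in this assay compound 2 gives > 100 nM, also a limit. Compound 3 `CNC(=O)NCc1nc(-c2ccc(OC)cc2)c(-c2ccc(OC)cc2)s1`: in this assay compound 3 gives 22 nM.

Compound 2 thus stands at the limit of > 100 nM in this assay, at which 2 of the 3 values shown sit, with no number of its own. Compound 4 `CCN(CC)C(=O)c1nc(-c2ccc(OC)cc2)c(-c2ccc(OC)cc2)s1` differs from compound 2 by a group of 7 heavy atoms (5 carbon, 1 nitrogen, 1 oxygen; no ring) in place of a group of 7 heavy atoms (4 carbon, 3 nitrogen; no ring), on an aromatic carbon. Among the compounds with values here, the only readable step from compound 2 is an at least 4.5-fold lower number from compound 2 to compound 3 (0.65 log units; beyond the scatter), where the same leaving group gave way to a group that, like diethylcarbamoyl, carries a carbonyl; a step that the two limits leave unreadable from compound 1 to compound 2 cannot be sized. A drop of comparable size is expected. Compound 4 is estimated at 40 nM, between 10 nM and 200 nM, an expected step of an at least 2.5-fold lower number from compound 2 to compound 4 (0.39 log units; beyond the scatter).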

Compound 4, half-maximal inhibitory concentration: < 10 nM
Compound 4: no number, only a limit; the forecaster's own chance of this, stated with the estimate: 35%; middle value at least 4.0-fold (0.60 log units) away from the limit.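

In this assay compound 4 gives < 10 nM, which is a limit of the assay, so every step to it is a bound. Diethylcarbamoyl on this aromatic carbon gives an at least 10-fold lower number from compound 2 to compound 4 (1.00 log units; beyond the scatter) and an at least 10-fold lower number from compound 1 to compound 4 (1.00 log units; beyond the scatter), and it also goes past the urea-bearing group of compound 3, with an at least 2.2-fold lower number from compound 3 to compound 4 (0.34 log units; beyond the scatter). Since diethylcarbamoyl counts 0 hydrogen-bond donors, a low number at this position does not depend on a donor in the group.

On these data alone, how far compound 4 lies past its limit stays open. So does whether a smaller amide, such as dimethylcarbamoyl, or a carboxylic acid would hold this level.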